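Diketone chain on the dimethoxyphenyl core: methoxy removal

The source may hold more compounds than are shown below. What is called first, only, known or untested is meant among the compounds shown, and "the series" means these compounds.

Measured compounds:
compound 1 `Cc1cc(/C=C/c2ccc(O)cc2)[nH]n1` gives 32900 nM
compound 2 `COc1ccc(/C=C/c2cc(C)no2)cc1OC` gives > 100000 nM
compound 3 `COc1ccc(/C=C/C(=O)CC(C)=O)cc1OC` gives 9300 nM

All three were tested in a functional assay on S1 cells (Homo sapiens) for cytotoxicity, read by MTT assay, with a stated time of 72 h; on this read-out lower numbers stand for stronger inhibition and higher numbers for weaker inhibition. The value of compound 2 is a limit of the assay (the limit of > 100000 nM in this assay, at which 1 of the 3 values shown sits). Among the two actual numbers, compound 3 gives the lowest; its nearest neighbour is compound 1, which sits beyond the scatter above it. Among the measured compounds shown here, the one step measured, an at least 10-fold lower number from compound 2 to compound 3 (1.03 log units; beyond the scatter), concerns the group on the double-bonded chain carbon and not the aromatic ring.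

Compound 4 `COc1ccc(/C=C/C(=O)CC(C)=O)cc1` is not yet measured. It differs from compound 3 by hydrogen in place of methoxy on an aromatic carbon. For the measured compounds named here, no measured step touches a methoxy on the aromatic ring; the one measured step concerns a different place and offers no direction for this change. With nothing in the series pointing either way, the expectation for compound 4 in this assay is a step that stays within the scatter, a 1.3-fold higher number from compound 3 to compound 4 (0.11 log units; within the scatter). Compound 4 is therefore estimated at 12000 nM, with a range from 4000 nM to 40000 nM.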

Compound 4, half-maximal inhibitory concentration: 44600 nM
Compound 4: middle estimate off by 3.7-fold (0.57 log units), on the low side, outside the stated range (above it).
By their numbers in this assay, from the lowest: compound 3; then compounds 1 and 4 (each within the scatter of the next). At a limit, above all of these: compound 2.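

In this assay, among the compounds shown here, the aromatic carbon ortho to a methoxy group and meta to the group of 8 heavy atoms is the first place on the ring where a change has been read: a 4.8-fold higher number from compound 3 to compound 4 (0.68 log units; beyond the scatter). For the compounds shown here, until now the only measured step concerned the group on the double-bonded chain carbon, so the diketone chain on its own does not set the number, and this methoxy counts as well on the shared core. Nothing measured in the series bears on what lies behind the step, which stands here as an observation only.

The compounds shown leave open whether the methoxy itself matters at this carbon or whether another group would serve, for instance an ethoxy or an amine in its place, measured against compound 3 at 9300 nM on the same chain. Also open, from the compounds shown here alone, is whether removing a methoxy has a step of similar size when the chain carries a different group, and whether the other methoxy, taken away instead, behaves as this one does.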